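The compounds below may be only part of what the source reports. "The series", "measured", "known", "first", "only" and "open" are said of these compounds alone.

Three compounds share one core and differ only in what is attached to the aromatic nitrogen. Compound 1 `CN1CCN(CCCCCCn2c3c(c4ccccc42)C(=O)c2c[n+]([O-])c4ccccc4c2C3=O)CC1` carries a long chain ending in a methylpiperazine; in a functional assay on A-375 cells (Homo sapiens) for cytotoxicity, read by MTT assay, with a stated time of 72 h (on this read-out lower numbers stand for stronger inhibition and higher numbers for weaker inhibition), compound 1 gives 630 nM. Compound 2 `O=C1c2c[n+]([O-])c3ccccc3c2C(=O)c2c1c1ccccc1n2Cc1cn(C[C@@H](O)CO)nn1` instead carries a triazole bearing a 2,3-dihydroxypropyl group, and in this assay compound 2 gives 140 nM, the lowest of the three numbers. Compound 3 `O=C1c2c[n+]([O-])c3ccccc3c2C(=O)c2[nH]c3ccccc3c21` has only hydrogen on that nitrogen and gives 660 nM. The two measured steps are of similar size: a 4.5-fold lower number from compound 1 to compound 2 (0.65 log units; beyond the scatter) and a 4.7-fold higher number from compound 2 to compound 3 (0.67 log units; beyond the scatter). Together they show that the triazole with its dihydroxypropyl group is worth a modest step relative to either a bare nitrogen or the piperazine chain.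

Compound 4 `O=C1c2c[n+]([O-])c3ccccc3c2C(=O)c2c1c1ccccc1n2Cc1cn([C@@H]2C[C@H](O)[C@@H](CO)O2)nn1` keeps the triazole but changes the group on it: 4-hydroxy-5-(hydroxymethyl)oxolan-2-yl in place of 2,3-dihydroxypropyl on an aromatic nitrogen. For the measured compounds named here, no measured step alters this group alone; the triazole arm is retained in full, and the change swaps one hydroxy-bearing fragment for another, ring-shaped one. The nearest guidance, the steps into and out of compound 2, both concern far larger changes. A step no greater than the scatter is therefore expected, leaning neither way with confidence; for compound 4 the expected value is 200 nM, within 80 nM to 500 nM, which means an estimated 1.4-fold higher number from compound 2 to compound 4 (0.15 log units; within the scatter).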

Compound 4, half-maximal inhibitory concentration: 20 nM
The estimate for compound 4 lay 10-fold (1.00 log units) above the measured number, and the stated range ends above it.
By their numbers in this assay, from the lowest: compound 4; then compound 2; then compounds 1 and 3 (each within the scatter of the next).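

The earlier steps shown here changed the whole arm on the core's nitrogen, and they left open whether the far end of that arm matters once the triazole is in place. It does: with the triazole kept, 4-hydroxy-5-(hydroxymethyl)oxolan-2-yl in place of 2,3-dihydroxypropyl gives a 7.0-fold lower number from compound 2 to compound 4 (0.85 log units; beyond the scatter) in this assay, so the group on the triazole's aromatic nitrogen can shift the number beyond the scatter by itself. The two groups carry the same count of hydrogen-bond donors, so this step comes with other differences (a five-membered non-aromatic ring, an added ring oxygen, more heavy atoms and more defined stereocentres), and no measurement shown explains how any of them relates to the lower number.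

A single pair cannot separate these differences, and a plain oxolan-2-yl group without its hydroxy and hydroxymethyl groups, or a cyclopentyl ring, would show whether the ring alone goes with the lower number. The compounds shown also leave open how the number responds to the mirror-image arrangement of the ring's stereocentres, or to a six-membered tetrahydropyranyl ring at the same place.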